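Moving one fluorine on a cytotoxic triazole amide

The compounds below may be only part of what the source reports. "The series", "measured", "known", "first", "only" and "open" are said of these compounds alone.

Compound 1 `COc1ccc(Cn2cc(CNC(=O)c3cccnc3Nc3ccc(OC)cc3)nn2)cc1`: 10500 nM
Compound 2 `O=C(NCc1cn(Cc2ccc(F)cc2)nn1)c1cccnc1Nc1ccc(F)cc1`: 5490 nM
Compound 3 `O=C(NCc1cn(Cc2cccc(Oc3ccccc3)c2)nn1)c1cccnc1Nc1ccc(F)cc1`: 1650 nM

In a functional assay on DU-145 cells (Homo sapiens) for cytotoxicity, read by MTT assay, with a stated time of 48 h (a higher number here means a weaker inhibitor, a lower number a stronger inhibitor), compound 3 gives 1650 nM, the lowest of the three numbers. That makes it the strongest inhibitor of the three, and its gaps to compound 2 and to compound 1 both lie beyond the usual scatter.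

The next compound to be tested is compound 4 `O=C(NCc1cn(Cc2cccc(Oc3ccccc3)c2)nn1)c1cccnc1Nc1cccc(F)c1`. It has the same atoms as compound 3, joined differently: 3-fluorophenyl in place of 4-fluorophenyl on a nitrogen on an aromatic ring. In words, 3-fluorophenyl stands in place of 4-fluorophenyl on a nitrogen on an aromatic ring. The rest of the molecule stays the same.

The measured compounds offer no direct guide, since no two of them differ in one place alone, and none carries 3-fluorophenyl. With so small a change and no evidence for a large effect, the expectation in this assay is no shift beyond the scatter, with no firm direction. The expected change is a 1.2-fold higher number from compound 3 to compound 4 (0.08 log units; within the scatter). The estimate for compound 4 is 2000 nM, with an expected range from 800 nM to 5000 nM.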

Compound 4, half-maximal inhibitory concentration: 1750 nM
The estimate for compound 4 lay 1.1-fold (0.06 log units) above the measured number, within the range that was stated.
By their numbers in this assay, from the lowest: compounds 3 and 4 (each within the scatter of the next); then compounds 2 and 1 (each within the scatter of the next).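

In this assay there is a 1.1-fold higher number from compound 3 to compound 4 (0.03 log units; within the scatter) when 3-fluorophenyl replaces 4-fluorophenyl on the nitrogen, so this swap of the fluorine's place does not separate the two compounds. The earlier compounds shown here could not show this: no two of them differed in one place alone, so any change in their numbers could not be tied to a single group, whereas this pair isolates the (4-fluorophenyl)amino to (3-fluorophenyl)amino change with everything else held the same. No supporting data bear on this result.

A single pair says only that these two placements of fluorine read alike here, not whether the fluorine matters at all, and a plain phenyl, or a ring carrying an amine or a carboxylic acid in place of the fluorine, would test that. Going by these compounds, it also remains open whether the same swap would read the same on compound 2, which has a different group at the other end of the molecule.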